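Amino for chloro: one change repeated in two cores

The source may report more compounds than this note shows. Statements on the series, on what has been measured and on what is new or still open speak of the compounds shown alone.

Compound 1 `ClCc1ccccc1Cn1cnc2c(Cl)nc(Cl)nc21` and compound 2 `ClCc1cccc(Cn2cnc3c(Cl)nc(Cl)nc32)c1` share the same atoms joined differently; the difference between the two cores is not broken down here. In a functional assay on EKVX cells (Homo sapiens) for cytotoxicity, read by sulforhodamine B assay, with a stated time of 48 h (a lower number here means a stronger inhibitor of growth, a higher number a weaker inhibitor of growth), compound 1 gives 1770 nM and compound 2 gives 1730 nM, the two lying within the scatter of each other. Compound 3 `Nc1nc(Cl)c2ncn(Cc3ccccc3CCl)c2n1` arises from compound 1 by the change (amino in place of chloro on an aromatic carbon); compound 3 gives 15900 nM, and the change produced a 9.0-fold higher number from compound 1 to compound 3 (0.95 log units; beyond the scatter). Compound 4 `Nc1nc(Cl)c2ncn(Cc3cccc(CCl)c3)c2n1`, not yet measured, arises from compound 2 by the change (amino in place of chloro on an aromatic carbon), the same change at a place described in identical words. A step of similar size is expected here, roughly an 8.4-fold higher number from compound 2 to compound 4 (0.92 log units; beyond the scatter) in this assay, because a 9.0-fold higher number from compound 1 to compound 3 (0.95 log units; beyond the scatter) followed the same change on a core whose value matched. Compound 4 is therefore estimated at 14500 nM, within 6000 nM to 35000 nM.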

Compound 4, concentration for 50% growth inhibition: 21400 nM
Compound 4: middle estimate off by 1.5-fold (0.17 log units), on the low side; low and high end bracket the measured number.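

In this assay, amino in place of chloro on an aromatic carbon gives a 12-fold higher number from compound 2 to compound 4 (1.09 log units; beyond the scatter), and this step does not differ beyond the scatter from the one on the other core: the same change on two cores in this assay, a 9.0-fold higher number (0.95 log units; beyond the scatter) from compound 1 to compound 3 and a 12-fold higher number (1.09 log units; beyond the scatter) from compound 2 to compound 4, 1.4-fold (0.14 log units) apart, within the scatter of two such steps. Within this series, the change raises the number on both cores, and the size of the step seen on one core held on the other. This rests on two pairs in one assay and does not show why the number rises, nor whether the step holds on a core outside these two.

Going by these compounds, whether a methoxy or methylamino group in the same place would give a step of like size remains open. So does whether the step persists when the chloromethyl group gives way to a hydroxymethyl group.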